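Swapping the Sulfonyl Aryl Group of a Receptor Binder

The source may hold more compounds than are shown below. What is called first, only, known or untested is meant among the compounds shown, and "the series" means these compounds.

Compound 1 `CC1CCN(c2c(S(=O)(=O)c3ccc(F)c(F)c3)cnc3cc(F)ccc23)CC1` gives 94% in an assay on isolated protein for displacement of a labelled ligand from metabotropic glutamate receptor 5 (Homo sapiens), with a stated time of 60 min, tested at 1 uM; on this read-out lower numbers stand for less inhibition and higher numbers for more inhibition at the one concentration tested (going by the name of the read-out).
Compound 2 `Cc1ccc(S(=O)(=O)c2cnc3ccc(Cl)cc3c2N2CCC(C)CC2)cc1Cl` gives 81% in this assay.
Compound 3 `CC1CCN(c2c(S(=O)(=O)c3ccc(F)c(F)c3)cnc3cc(Cl)ccc23)CC1` gives 90% in this assay.

Among these three numbers compound 1 stands highest. Its nearest neighbour is compound 3, reached by a number 4 percentage points lower from compound 1 to compound 3 (within the scatter), a change of chloro in place of fluoro on an aromatic carbon that leaves the read-out essentially where it was. Compound 2 lies further off, its number being beyond the scatter below that of compound 1, but compound 2 differs from compound 1 in more than one place, so no single step can be read from that pair.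

Compound 4 `Cc1ccc(S(=O)(=O)c2cnc3cc(F)ccc3c2N2CCC(C)CC2)cc1` has not yet been measured in this assay. It differs from compound 1 as follows: 4-methylphenyl in place of 3,4-difluorophenyl on a sulfonyl sulfur. For the measured compounds named here, none of the measured steps touches the group on the sulfonyl sulfur; the only single-place step measured concerns a halogen on the shared core, and it lay within the scatter. The change to compound 4 is therefore one for which the measured compounds give no direct guide, and the number for compound 4 is expected to stay high with a modest drop, a number 9 percentage points lower from compound 1 to compound 4 (within the scatter). Compound 4 is estimated at 85%, within a range from 65% to 96%.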

Compound 4, a percentage reported as inhibition, at one concentration (the size of the read-out at that concentration, not a potency): 88%
The estimate for compound 4 lay 3 percentage points below the measured number; the measured number falls inside the stated range.
By their numbers in this assay, from the lowest: compounds 2, 4, 3 and 1 (each within the scatter of the next, the first and the last beyond it).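

For the compounds shown here, this is the first single-place step at the sulfonyl sulfur: in this assay, 4-methylphenyl in place of 3,4-difluorophenyl gives a number 6 percentage points lower from compound 1 to compound 4 (within the scatter) and so leaves the read-out essentially where it was. At this place and on this core, then, the aromatic ring keeps its high number with a methyl group and neither fluorine, which means that the two fluorines are not needed for a high reading at the one concentration tested. The compounds shown offer no measured information that could explain why the two groups give such similar readings.

As far as these compounds go, both groups are carbon-only aromatic rings, so it remains open whether the number would stay level for a ring carrying an amine or a carboxylic acid, or for a longer alkyl chain replacing the whole ring. From the compounds shown here alone, it is also open whether the swap behaves the same way with chloro in place of fluoro on the shared core, as in compound 3, and whether full concentration-response measurements would separate compound 1 from compound 4, since a single-concentration reading is not a potency.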